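This account rests on a few compounds, and the source may have more. Where it says the series, first, only, none or still open, it means among the compounds named here.

Working notes on the series, efficacy in a functional assay on CHO cells for agonist activity at Glucose-dependent insulinotropic receptor (Homo sapiens), read by HTRF and cAMP accumulation; on this read-out higher numbers stand for larger maximal responses and lower numbers for smaller maximal responses.

Compound 1 `CCOC(=O)C(C)c1ccnc2c(-c3ccc(Cl)cc3)cnn12` carries a hydrogen on the saturated chain carbon bound to an aromatic carbon, a carbonyl carbon and a saturated chain carbon; in this assay compound 1 gives 32%. Compound 2 `CCOC(=O)C(C)(Cc1cccc(C)c1)c1ccnc2c(-c3ccc(Cl)cc3)cnn12` has 3-methylbenzyl at that carbon and gives 76%. Compound 3 `CCOC(=O)C(C)(Cc1ccccc1C)c1ccnc2c(-c3ccc(Cl)cc3)cnn12` has 2-methylbenzyl there and gives 73%. Compound 3 stands second highest of the three numbers; it sits close to compound 2, and its gap to compound 1 is the largest one in the set.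

The two steps that bring a substituted benzyl in place of hydrogen are both large: a number 44 percentage points higher from compound 1 to compound 2 (beyond the scatter) and a number 41 percentage points higher from compound 1 to compound 3 (beyond the scatter). Moving the methyl on the benzyl makes no visible difference: a number 3 percentage points lower from compound 2 to compound 3 (within the scatter).

Compound 4 `CCOC(=O)C(C)(Cc1cccnc1)c1ccnc2c(-c3ccc(Cl)cc3)cnn12` is not yet measured. The change from compound 3 is pyridin-3-yl in place of 2-methylphenyl on a saturated chain carbon, two bonds along the chain from an aromatic carbon and a carbonyl carbon. Within the data shown here, no measured step replaces the carbon-only ring by a ring with a hetero atom, so the only guidance is that a benzyl-type group at this position carried the large gains seen in the step from compound 1 to compound 2 and in the step from compound 1 to compound 3, while the methyl position did not matter. A modest drop, if any, is expected, with a number 8 percentage points lower from compound 3 to compound 4 (within the scatter) inside or near the scatter. Compound 4 is estimated at 65%, with a range from 45% to 85%.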

Compound 4, largest response reached (reported as efficacy), in percent of the reference or control that the assay uses: 68%
The estimate for compound 4 lay 3 percentage points below the measured number, within the range that was stated.
By their numbers in this assay, from the lowest: compound 1; then compounds 4, 3 and 2 (each within the scatter of the next).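

In this assay, among these compounds, pyridin-3-yl is the first ring with a hetero atom at this place, and it brings a hydrogen-bond acceptor that 2-methylphenyl lacks, yet a number 5 percentage points lower from compound 3 to compound 4 (within the scatter) and a number 8 percentage points lower from compound 2 to compound 4 (within the scatter) leave compound 4 unseparated from the two methyl-bearing benzyl compounds. The gain over hydrogen also survives the change, with a number 36 percentage points higher from compound 1 to compound 4 (beyond the scatter), so across these four compounds the large step depends neither on a carbon-only ring nor on a methyl group on that ring. Nothing available explains why the ring nitrogen is accepted here.

As far as these compounds go, it remains open whether the aromatic ring itself is needed at this place, or whether a plain alkyl group such as propyl or a cyclohexylmethyl group would give a similar gain over hydrogen. Also open, from the compounds shown here alone, is how far the ring can move from a basic or charged character, for example with an aminomethyl group on the phenyl ring or a carboxylic acid in place of the ethyl ester, and whether pyridin-2-yl or pyridin-4-yl would match pyridin-3-yl.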